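The compounds below may be only part of what the source reports. "The series", "measured", "known", "first", "only" and "open" are said of these compounds alone.

Working notes on the sulfonamide series.

Three compounds carry a value in an ADME assay (liver) for metabolic stability, with Liver microsome (Homo sapiens) as the target, read by LC-MS, using microsomes and NADPH, with a stated time of 5 min, at 37 degrees C (a lower number here means slower removal, a higher number faster removal of the compound), so far. Compound 1 `CCn1c([C@@H](C)NS(=O)(=O)c2ccc(Cl)cc2)nc2ccc(S(C)(=O)=O)cc21` sits at the limit of the assay: in this assay compound 1 gives < 5 mL.min-1.g-1, which is a limit and not a number, as the limit of < 5 mL.min-1.g-1 in this assay, at which 1 of the 3 values shown sits, records. Compound 2 `CCn1c([C@@H](C)NS(=O)(=O)c2ccc(Cl)cc2)nc2cccc(Cl)c21` also returns only a limit: in this assay compound 2 gives > 100 mL.min-1.g-1. Within the data shown here, compound 3 `CCn1c([C@@H](C)NS(=O)(=O)c2cccc(Cl)c2)nc2ccc(C(F)(F)F)cc21` stands at the same bound as compound 2: in this assay compound 3 gives > 100 mL.min-1.g-1, a limit rather than a measured number, and the limit of > 100 mL.min-1.g-1 in this assay, at which 2 of the 3 values shown sit, shows that two of the three values so far rest there. No single-point comparison between measured compounds exists in this set, so the spread between compound 1 and the other two is noted only as what the two bounds show.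

The next compound, compound 4 `CCCn1ncc(S(=O)(=O)N[C@H](C)c2nc3ccc(C(F)(F)F)cc3n2CC)c1C`, differs from compound 3 in one place on the sulfonyl sulfur: 5-methyl-1-propyl-1H-pyrazol-4-yl in place of 3-chlorophenyl on a sulfonyl sulfur.

The expected step from compound 3 to compound 4 in this assay is a modest drop, an at least 1.4-fold lower number from compound 3 to compound 4 (0.15 log units; that floor lies within the scatter), since compound 3 gives only the upper limit > 100 mL.min-1.g-1 and the new value may fall back into the measurable range. Compound 4 is estimated at 70 mL.min-1.g-1, with a likely range from 25 mL.min-1.g-1 to 150 mL.min-1.g-1.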

Compound 4, intrinsic clearance in microsomes: > 100 mL.min-1.g-1
Compound 4: a limit, no number (the forecaster's own chance of this, stated with the estimate: 40%); middle value at least 1.4-fold (0.15 log units) away from the limit.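

Compound 3 and compound 4 both rest at a limit and not at a number in this assay, so no step between them can be read: the limit of > 100 mL.min-1.g-1 in this assay, at which 3 of the 4 values shown sit.

The compounds shown leave open whether 5-methyl-1-propyl-1H-pyrazol-4-yl in place of 3-chlorophenyl on a sulfonyl sulfur changes intrinsic clearance in microsomes at all, and by how much.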